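Permeability notes on a sulfonamide amide series

A few compounds are considered here, and "the series" means these few. Any claim that something is new, unique, unknown or untested is made for them only; others in the source may bear on it.

Measured so far:
- Compound 1 `Cc1noc(CNC(=O)c2ccc(C)c(S(=O)(=O)Nc3ccc(-c4cnco4)cc3)c2)n1`: 10 10^-6 cm/s
- Compound 2 `Cc1ccc(C(=O)NCc2cn(C)nn2)cc1S(=O)(=O)Nc1ccc(-c2ccno2)cc1`: 12 10^-6 cm/s

In an ADME assay on MDCK-II cells (Canis lupus familiaris) for permeability (a higher number here means that the compound crosses the layer faster, a lower number that the compound crosses the layer more slowly), compound 2 gives the higher of the two numbers, but its nearest neighbour, compound 1, gives a value within the scatter of it, so no order between the two can be read.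

Compound 3 `Cc1noc(CNC(=O)c2ccc(C)c(S(=O)(=O)Nc3ccc(-c4ccno4)cc3)c2)n1` is not yet measured. It differs from compound 2 by 3-methyl-1,2,4-oxadiazol-5-yl in place of 1-methyl-1H-1,2,3-triazol-4-yl on a saturated chain carbon bound to an amide-type nitrogen. Among the compounds with values here, no measured pair shows this exact step, so its size is not known from the series. Compound 1, which also carries the 3-methyl-1,2,4-oxadiazol-5-yl group on a saturated chain carbon bound to an amide-type nitrogen, gives 10 10^-6 cm/s in this assay, close to compound 2.

On that basis compound 3 is expected to sit near both measured values, with the step of a 1.1-fold lower number from compound 2 to compound 3 (0.04 log units; within the scatter) estimated to stay within the scatter. The estimate for compound 3 is 11 10^-6 cm/s, range 6 10^-6 cm/s to 20 10^-6 cm/s.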

Compound 3, apparent permeability: 6 10^-6 cm/s
For compound 3 the middle estimate is 1.8-fold (0.26 log units) above the measured one, within the range that was stated.
By their numbers in this assay, from the lowest: compounds 3, 1 and 2 (each within the scatter of the next).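

In this assay, replacing 1-methyl-1H-1,2,3-triazol-4-yl with 3-methyl-1,2,4-oxadiazol-5-yl on a saturated chain carbon bound to an amide-type nitrogen gives a 2.0-fold lower number from compound 2 to compound 3 (0.30 log units; within the scatter) and now has a measured size. On an aromatic carbon, 1,2-oxazol-5-yl in place of 1,3-oxazol-5-yl gives a 1.7-fold lower number from compound 1 to compound 3 (0.22 log units; within the scatter), so neither single change separates its pair of compounds. Nothing further in the data accounts for either step.

On these data alone, each step rests on one pair of compounds, so whether either size carries over to other members remains open. Also open, as far as these compounds go, is whether an amine, a carboxylic acid or a longer chain on that saturated chain carbon would give a step beyond the scatter.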